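The source may hold more compounds than are shown below. What is called first, only, known or untested is meant among the compounds shown, and "the series" means these compounds.

Working notes on the methoxyaryl series in a functional assay on MDA-MB-231 cells (Homo sapiens) for cytotoxicity, read by MTT assay; on this read-out lower numbers stand for stronger inhibition and higher numbers for weaker inhibition.

Among the compounds with values here, compound 1 `COc1ccc(-n2cc(-c3ccc(OC)c(OC)c3)nn2)cc1` is the only member with a reported read-out. In this assay compound 1 gives > 100 nM, which is a limit of the assay and not a number (the limit of > 100 nM in this assay, at which 1 of the 3 values shown sits). Compound 2 `COc1ccc(-c2cn(-c3cc(OC)c(OC)c(OC)c3)nn2)cc1OC` carries a trimethoxy-substituted aryl group at the second aryl position; in this assay compound 2 gives "not determined" (no result reported). Compound 3 `COc1ccc(-c2cn(-c3ccc(OC)c(OC)c3)nn2)cc1OC` carries a dimethoxy-substituted aryl group at that position; in this assay compound 3 gives "not determined" (no result reported). Compound 3 therefore stands nowhere on a scale: no single number exists for it, one further entry in the set is a limit and one further entry is absent.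

Compound 4 `COc1ccc(-c2cn(-c3ccc(OC)c(OC)c3)nn2)cc1` is not yet measured. It differs from compound 3 by hydrogen in place of methoxy on an aromatic carbon. Within the data shown here, no step between two measured compounds exists in this set, so neither the size nor the direction of this change can be read from the data, and it may well lie within the usual scatter. Among the measured compounds shown here, the only anchor is compound 1, whose value is a limit.

Compound 4 is expected to give about 300 nM in this assay, with a range from 80 nM to 3000 nM, and a real chance that only a limit is reported.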

Compound 4, half-maximal inhibitory concentration: > 10000 nM
Compound 4 ended at the assay's limit; the forecaster's own chance of this, stated with the estimate: 60%; at least 33-fold (1.52 log units) between middle value and limit.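

No step can be read between compound 3 and compound 4: compound 3 has no single number in this assay. In this assay compound 4 gives > 10000 nM, which is a limit of the assay and not a number. The compounds shown leave open the size and direction of any change in this assay when hydrogen replaces methoxy on an aromatic carbon.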